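Sulfonamide to urea on a weakly inhibiting biaryl

The source may report more compounds than this note shows. Statements on the series, on what has been measured and on what is new or still open speak of the compounds shown alone.

Measured compounds:
compound 1, `CCOC(=O)c1cccc(-c2ccc3c(ccn3C)c2)c1`, 75000 nM
compound 2, `CCOc1ccc(-c2cccc(S(=O)(=O)N(C)C)c2)cc1`, 110000 nM

In an assay on COS-7 cells for inhibition of patatin-like phospholipase domain-containing protein 2 (Mus musculus) (a higher number here means a weaker inhibitor, a lower number a stronger inhibitor), compound 1 gives 75000 nM and compound 2 gives 110000 nM; the two numbers lie within the usual scatter of each other, so neither stands apart. Compound 3, `CCOc1ccc(-c2cccc(NC(=O)N(C)C)c2)cc1`, has not been measured. It differs from compound 2 in one place: (dimethylcarbamoyl)amino in place of dimethylsulfamoyl on an aromatic carbon. Among the measured compounds shown here, no measured pair shows this change, so there is no basis for a direction, and no shift beyond the scatter is expected from compound 2 to compound 3 in this assay, that is a 1.1-fold lower number from compound 2 to compound 3 (0.04 log units; within the scatter). Compound 3 is therefore estimated at 100000 nM, between 30000 nM and 300000 nM.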

Compound 3, half-maximal inhibitory concentration: 70000 nM
Beside the measured number, compound 3's estimate is 1.4-fold (0.15 log units) above it, and the stated range covers the measured number.
By their numbers in this assay, from the lowest: compounds 3, 1 and 2 (each within the scatter of the next).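

In this assay, placing (dimethylcarbamoyl)amino in place of dimethylsulfamoyl on this aromatic carbon gives a 1.6-fold lower number from compound 2 to compound 3 (0.20 log units; within the scatter). This single-place pair shows that the position accepts this exchange, which adds a hydrogen-bond donor, with no difference that stands clear of the scatter. No available evidence accounts for the two groups reading alike. Going by these compounds, whether another group on this carbon, such as a carboxylic acid or a primary amine, would move the number beyond the scatter remains open.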